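Changing the Nitrogen Side Chain of Compound 1

This account rests on a few compounds, and the source may have more. Where it says the series, first, only, none or still open, it means among the compounds named here.

Going by the values given here, compound 1 `CC(C)n1cc(C(=O)C(=O)Nc2ccc(C(F)(F)F)nc2)c2ccccc21` is one of three compounds measured in a functional assay on FaDu cells (Homo sapiens) for cytotoxicity, read by MTT assay, with a stated time of 72 h; on this read-out lower numbers stand for higher toxicity in this test and higher numbers for lower toxicity in this test. In this assay compound 1 gives > 10000 nM, which is a limit of the assay rather than a number. Compound 2 `COc1ccc(NC(=O)C(=O)c2cn(C(C)C)c3ccccc23)cn1` gives 85 nM in this assay. Compound 3 `CC(C)n1cc(C(=O)C(=O)Nc2cccnc2)c2ccccc21` also sits at a limit, giving > 10000 nM in this assay. The step from compound 1 to compound 2 is an at least 110-fold lower number from compound 1 to compound 2 (2.07 log units; beyond the scatter), the step from compound 2 to compound 3 is an at least 110-fold higher number from compound 2 to compound 3 (2.07 log units; beyond the scatter), and the step from compound 1 to compound 3 is a step that the two limits leave unreadable from compound 1 to compound 3; the limit of > 10000 nM in this assay, at which 2 of the 3 values shown sit, marks where two of the three values rest. Compound 4 `COCCn1cc(C(=O)C(=O)Nc2ccc(C(F)(F)F)nc2)c2ccccc21` differs from compound 1 in one place: 2-methoxyethyl in place of isopropyl on an aromatic nitrogen. Among the compounds with values here, each of the three measured steps concerns the group on an aromatic carbon, and none touches the aromatic nitrogen, so no measured step bears on this change. Compound 4 is therefore expected to remain near the limit, with a step that the limit leaves unreadable from compound 1 to compound 4 that cannot be read. The estimate for compound 4 is 15000 nM, expected to lie between 3000 nM and 60000 nM.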

Compound 4, concentration lethal to 50% of the cells: > 10000 nM
Compound 4: no number, only a limit (the forecaster's own chance of this, stated with the estimate: 75%); the middle value lies beyond the limit too.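

Going by these compounds alone, compound 1 and compound 4 both rest at a limit of the assay in this assay, so no step between them can be read: the limit of > 10000 nM in this assay, at which 3 of the 4 values shown sit.
The compounds shown leave open whether 2-methoxyethyl in place of isopropyl on the aromatic nitrogen changes the read-out at all, including when methoxy replaces trifluoromethyl, as in compound 2.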